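Swapping the Phenyl on the Anilinic Nitrogen for Cyclohexyl

The source may hold more compounds than are shown below. What is called first, only, known or untested is meant among the compounds shown, and "the series" means these compounds.

Compound 1 `O=c1cc(Nc2ccccc2)cc(-c2ccccc2)o1` carries a phenyl on the nitrogen that sits on its aromatic core. In a functional assay on A549 cells (Homo sapiens) for cytotoxicity, read by MTT assay, with a stated time of 72 h (a higher number here means that more compound is needed for the effect, a lower number that less compound is needed), compound 1 gives 0.12 uM, the highest of the two numbers recorded so far. Its nearest neighbour is compound 2 `COc1ccc(Nc2cc(-c3ccccc3)oc(=O)c2)cc1`, which in this assay gives 0.093 uM; the step of a 1.3-fold lower number from compound 1 to compound 2 (0.11 log units; within the scatter) comes from a methoxy in place of hydrogen on an aromatic carbon.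

Compound 3 `O=c1cc(NC2CCCCC2)cc(-c2ccccc2)o1` has not been measured. It differs from compound 1 in one place: cyclohexyl in place of phenyl on a nitrogen on an aromatic ring. The phenyl that leaves is one six-membered aromatic ring of carbon only; the cyclohexyl that enters is one six-membered non-aromatic ring of carbon only, so the count of heavy atoms, donors and acceptors does not change.

For the measured compounds named here, the only measured step, from compound 1 to compound 2, alters an aromatic carbon and not the nitrogen, so no recorded step bears on this change. The direction of the step in this assay therefore cannot be read from the data. Compound 3 is estimated to give 0.3 uM, within a wide range from 0.06 uM to 1.5 uM, which corresponds to an expected step of a 2.5-fold higher number from compound 1 to compound 3 (0.40 log units; beyond the scatter).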

Compound 3, concentration for half-maximal effect: 9.69 uM
Beside the measured number, compound 3's estimate is 32-fold (1.51 log units) below it; measured number outside the range, above it.
By their numbers in this assay, from the lowest: compounds 2 and 1 (each within the scatter of the next); then compound 3.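

In this assay, replacing the phenyl on the nitrogen with cyclohexyl gives an 81-fold higher number from compound 1 to compound 3 (1.91 log units; beyond the scatter) and moves compound 3 well away from the two earlier compounds. The earlier step, a 1.3-fold lower number from compound 1 to compound 2 (0.11 log units; within the scatter), only added a methoxy to an aromatic carbon and stayed within the scatter, so it gave no sign that the number could move at all; this step shows that the number responds strongly to what sits on this nitrogen. The two groups match in heavy atoms, hydrogen-bond donors and hydrogen-bond acceptors, and they are told apart only by one ring being aromatic and the other non-aromatic, so those counts do not separate phenyl from cyclohexyl here.

The compounds shown leave open whether other groups on this nitrogen, such as a benzyl group, a pyridine ring or a longer chain like hexyl, would give numbers close to compound 1 or close to compound 3. Nothing at hand accounts for the size of this step, so its cause remains unknown.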